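Compound 3: a larger group replaces a small one

The compounds below may be only part of what the source reports. "The series", "measured", "known", "first", "only" and "open" are said of these compounds alone.

Measured in a functional assay on RKO cells (Homo sapiens) for inhibition, read by MTT assay, with a stated time of 48 h; a lower number here means a stronger inhibitor, a higher number a weaker inhibitor:
compound 1 `COc1ccc(N(C)c2nc(C)nc3ccccc23)cc1OCCC[Se]C#N`: 799 nM
compound 2 `COc1ccc(N(C)c2nc(C)nc3ccccc23)cc1[Se]C`: 11 nM

Of the two measured compounds, compound 2 has the lower number, 11 nM, and is the stronger inhibitor of the pair. Compound 3 `COc1ccc(N(C)c2nc(C)nc3ccccc23)cc1OCCCC[Se]C#N` has not yet been measured. It differs from compound 2 as follows: a group of 8 heavy atoms (5 carbon, 1 nitrogen, 1 oxygen, 1 selenium; no ring) in place of a group of 2 heavy atoms (1 carbon, 1 selenium; no ring), on an aromatic carbon. The site is ortho to a methoxy group.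

Going by the values given here, one measured step bears on this change: a 73-fold lower number from compound 1 to compound 2 (1.86 log units; beyond the scatter). That large step, beyond the scatter, came with a group of 7 heavy atoms leaving, whereas here a group of 8 heavy atoms enters. A large rise in this assay is therefore expected, of about the same size as the step from compound 1. The estimated change is a 64-fold higher number from compound 2 to compound 3 (1.80 log units; beyond the scatter). For compound 3 the estimated value is 700 nM, with an expected range of 250 nM to 2000 nM.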

Compound 3, half-maximal inhibitory concentration: 1360 nM
Beside the measured number, compound 3's estimate is 1.9-fold (0.29 log units) below it; the measured number falls inside the stated range.
By their numbers in this assay, from the lowest: compound 2; then compounds 1 and 3 (each within the scatter of the next).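

In this assay, the step of a 120-fold higher number from compound 2 to compound 3 (2.09 log units; beyond the scatter) shows that the large rise seen with compound 1 is not confined to a single chain: at this aromatic carbon, ortho to a methoxy group, a second chain ending in selenium and nitrile also stands far from the small group of compound 2. The step of a 1.7-fold higher number from compound 1 to compound 3 (0.23 log units; within the scatter) lies within the scatter, so in this assay the two chains do not separate from each other. Nothing measured here accounts for the gap to compound 2.

From the compounds shown here alone, it remains open whether the rise follows the chain itself or its selenium and nitrile end, as a plain butoxy group at this carbon would test. Equally open, going by these compounds, is how a much shorter or longer chain, or one ending in an amine or a carboxylic acid, would read in this assay.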